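Working notes: chloro for fluoro, one pending compound

The source may hold more compounds than are shown below. What is called first, only, known or untested is meant among the compounds shown, and "the series" means these compounds.

Measured so far:
compound 1, `CCOC(=O)C1=CC(c2ccccc2)C2=C(CC(C)(C)CC2=O)N1`: "not active" (no number reported)
compound 2, `CC1(C)CC(=O)C2=C(C1)NC(c1ccccc1)=CC2c1ccc(Cl)cc1`: 7.16%
compound 3, `CCOC(=O)C1=CC(c2ccc(F)cc2)C2=C(CC(C)(C)CC2=O)N1`: "not active" (no number reported)

In an assay on isolated protein for inhibition of glucose-6-phosphatase catalytic subunit 1 (Homo sapiens), read by inositol phosphate accumulation, with a stated time of 30 min, tested at 100 uM (a lower number here means less inhibition, a higher number more inhibition at the concentration tested (going by the name of the read-out)), compound 1 gives "not active" (no number reported), with no number reported. Compound 2 gives 7.16% in this assay, the only numbered entry of the three and a low one. Compound 3 gives "not active" (no number reported) in this assay, again with no number behind it. Compound 3 therefore stands without a figure, alongside compound 1 as a second entry of that kind, and below nothing that could be ordered.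

Compound 4, `CCOC(=O)C1=CC(c2ccc(Cl)cc2)C2=C(CC(C)(C)CC2=O)N1`, has not been run in this assay yet. It differs from compound 3 by the change (chloro in place of fluoro on an aromatic carbon); cut one bond further out, the 4-fluorophenyl becomes a 4-chlorophenyl. Going by the values given here, no measured pair covers this change, so no step can be read off. The expectation in this assay is a step of no size beyond the usual scatter, in either direction. Compound 2, which also carries a 4-chlorophenyl, gives 7.16% in this assay, which supports an expectation of weak inhibition at best. Compound 4 is estimated at 6% in this assay, expected to fall between 0% and 18%.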

Compound 4, a percentage reported as inhibition, at one concentration (the size of the read-out at that concentration, not a potency): 11.3%
The estimate for compound 4 lay 5.3 percentage points below the measured number; low and high end bracket the measured number.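

With the 4-chlorophenyl in place, the ethoxycarbonyl compounds gain their first figure in this assay: compound 3 gives "not active" (no number reported), whereas compound 4 gives 11.3%, so the step from fluoro to chloro cannot be read as a size. Between the two 4-chlorophenyl compounds, ethoxycarbonyl in place of phenyl on a double-bonded ring carbon gives a number 4.1 percentage points higher from compound 2 to compound 4 (within the scatter), so that exchange shows no separable difference at this low level of inhibition. Nothing available explains why one halogen comes with a figure and the other without.

From the compounds shown here alone, whether an amine or a methoxy group in place of the chloro on the aromatic ring would give inhibition clearly beyond that of compound 4 remains open. Equally open, going by these compounds, is how a carboxylic acid or a longer ester chain in place of the ethoxycarbonyl would read.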